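Moving the Methylsulfonyl Group Around the Pyridine of Compound 2

This account rests on a few compounds, and the source may have more. Where it says the series, first, only, none or still open, it means among the compounds named here.

The study measures antagonism of the first C-C chemokine receptor in a functional assay on cells for antagonist activity at C-C chemokine receptor type 1 (Homo sapiens), read by FLIPR and calcium flux; a higher number here means a weaker inhibitor, a lower number a stronger inhibitor. Compound 1, `O=C(NCc1cccc(C(F)(F)F)c1)c1cnn(-c2ccc(Cl)c(Cl)c2)c1`, gives only a limit of > 3000 nM in this assay, and the entry the limit of > 3000 nM in this assay, at which 1 of the 2 values shown sits, records that this is a boundary of the measurement rather than a number. Compound 2, `CCCC(NC(=O)c1cnn(-c2ccc(Cl)cc2)c1C)c1ccc(S(C)(=O)=O)nc1`, gives 47 nM in this assay. Going by the values given here, that is the only actual number among the two values shown; the other is the boundary just described for compound 1. Compound 3, `CCCC(NC(=O)c1cnn(-c2ccc(Cl)cc2)c1C)c1cncc(S(C)(=O)=O)c1`, has not yet been measured. It differs from compound 2 by 5-(methylsulfonyl)pyridin-3-yl in place of 6-(methylsulfonyl)pyridin-3-yl on a saturated chain carbon bound to an amide-type nitrogen and a saturated chain carbon, so the two share every atom and only the arrangement of the pyridine substituents changes. Among the compounds with values here, no step between measured compounds with a single change is available to guide the size of this move. The writer expects the change to cost potency, with a step of a 5.3-fold higher number from compound 2 to compound 3 (0.73 log units; beyond the scatter) expected beyond the usual scatter. Compound 3 is therefore estimated at 250 nM in this assay, with a range from 60 nM to 1500 nM.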

Compound 3, half-maximal inhibitory concentration: 15 nM
Estimate against measurement, compound 3: 17-fold (1.22 log units) above, outside the stated range (below it).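

Placing 5-(methylsulfonyl)pyridin-3-yl in place of 6-(methylsulfonyl)pyridin-3-yl on a saturated chain carbon bound to an amide-type nitrogen and a saturated chain carbon gives, in this assay, a 3.1-fold lower number from compound 2 to compound 3 (0.50 log units; beyond the scatter) and supplies the first single-change comparison between measured compounds in this series. Both groups carry the same atoms and the same counts of rings, donors and acceptors, so this modest gain shows that their arrangement alone can shift the reading at this position, and that the series holds its activity with the methylsulfonyl group in either of these two arrangements. Nothing among the data shown speaks to the reason for the difference.

The compounds shown leave open whether the ring nitrogen of the pyridine contributes to this gain, which a methylsulfonylphenyl group at the same place would test. They also leave open whether the methylsulfonyl group itself is needed, or whether a carboxylic acid, a primary amide or a methoxy group could stand in its place on 5-substituted pyridin-3-yl.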